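Three Arylsulfonyl Piperidines Without a Measurable Cytotoxicity Value

The compounds below may be only part of what the source reports. "The series", "measured", "known", "first", "only" and "open" are said of these compounds alone.

Measured compounds:
Compound 1 `CC1CCN(C2CCN(S(=O)(=O)c3ccc(F)cc3F)CC2)CC1` gives > 5000 nM in an ADME assay on HCT-116 cells (Homo sapiens) for cytotoxicity, read by CellTiter-Glo, with a stated time of 72 h (on this read-out lower numbers stand for stronger inhibition and higher numbers for weaker inhibition), a limit of the assay and not a number.
Compound 2 `Cc1nc(Cl)sc1S(=O)(=O)N1CCC(N2CCC(C)CC2)CC1` gives > 10000 nM in this assay, again a limit.
Compound 3 `Cc1ccc(S(=O)(=O)N2CCC(N3CCC(C)CC3)CC2)cc1C` gives > 5000 nM in this assay, also a limit.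

The three compounds share one core and differ only in the group on the sulfonyl sulfur. Every value is a limit. None of the steps between them can be read: a step that the two limits leave unreadable from compound 1 to compound 2, a step that the two limits leave unreadable from compound 1 to compound 3 and a step that the two limits leave unreadable from compound 2 to compound 3 are all of unreadable size. Compound 3 therefore stands where two of the three values sit, at the limit of > 5000 nM in this assay, at which 2 of the 3 values shown sit, while one value sits at the limit of > 10000 nM in this assay, at which 1 of the 3 values shown sits.

Compound 4 `CC1CCN(C2CCN(S(=O)(=O)c3ccc(C#N)cc3)CC2)CC1` differs from compound 3 by 4-cyanophenyl in place of 3,4-dimethylphenyl on a sulfonyl sulfur. Among the measured compounds shown here, the only measured steps that touch the group on the sulfonyl sulfur are the three unreadable ones, so no size or direction for this change can be drawn from them; all that is known is that each variation tried so far left the value at a limit in this assay. Compound 4 is accordingly expected to behave the same way, with an estimated 10000 nM and a range from 3000 nM to 50000 nM. The estimated step that the limit leaves unreadable from compound 3 to compound 4 is expected to stay within the scatter, if a number is reported at all.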

Compound 4, half-maximal inhibitory concentration: > 5000 nM
Compound 4: no number, only a limit (the forecaster's own chance of this, stated with the estimate: 85%); the middle value does not contradict the limit.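

Compound 4 also gives only a limit in this assay, so none of its steps to compound 1, compound 2 or compound 3 can be read. The compounds shown leave open what any of the four would give as an actual number in this assay, and whether the group on the sulfonyl sulfur affects that number at all.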